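The source may report more compounds than this note shows. Statements on the series, on what has been measured and on what is new or still open speak of the compounds shown alone.

Of the compounds shown here, three sharing one core have been tested in a functional assay on Ehrlich cells (Mus musculus) for antiproliferative activity, read by trypan blue exclusion, with a stated time of 2 h; a higher number here means a weaker inhibitor, a lower number a stronger inhibitor. Compound 1 `N#CC1=C(N)N(c2ccc(S(N)(=O)=O)cc2)C2=C(C(=O)CCC2)C1c1ccccc1` carries a phenyl group on a saturated ring carbon of the core. In this assay compound 1 gives > 100 ug/mL, which is a limit of the assay rather than a number. Compound 2 `Cc1ccc(C2C(C#N)=C(N)N(c3ccc(S(N)(=O)=O)cc3)C3=C2C(=O)CCC3)cc1` differs by methyl in place of hydrogen on an aromatic carbon, and in this assay compound 2 gives 50 ug/mL; this is an at least 2.0-fold lower number from compound 1 to compound 2 (0.30 log units; that floor lies within the scatter). Compound 3 `N#CC1=C(N)N(c2ccc(S(N)(=O)=O)cc2)C2=C(C(=O)CCC2)C1c1ccco1` differs from compound 1 by furan-2-yl in place of phenyl on a saturated ring carbon. In this assay compound 3 gives > 100 ug/mL, again a limit of the assay and not a number. There is a step that the two limits leave unreadable from compound 1 to compound 3 because of the limit of > 100 ug/mL in this assay, at which 2 of the 3 values shown sit, and an at least 2.0-fold higher number from compound 2 to compound 3 (0.30 log units; that floor lies within the scatter). Compound 4 `Cc1ccoc1C1C(C#N)=C(N)N(c2ccc(S(N)(=O)=O)cc2)C2=C1C(=O)CCC2` is not yet measured; it differs from compound 3 by methyl in place of hydrogen on an aromatic carbon. This is the same kind of change as that from compound 1 to compound 2, though the place differs: there the methyl sits on a six-membered aromatic ring of carbon only, para to a large group; here on a five-membered aromatic ring with 1 oxygen, next to the ring atom that bears a large group, two ring bonds from the ring oxygen. The step from compound 3 to compound 4 is expected to be an at least 1.2-fold lower number from compound 3 to compound 4 (0.09 log units; that floor lies within the scatter), resting on an at least 2.0-fold lower number from compound 1 to compound 2 (0.30 log units; that floor lies within the scatter). Since compound 3 sits at a limit, the result may again be a limit. In this assay compound 4 is expected to give 80 ug/mL, between 40 ug/mL and 200 ug/mL.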

Compound 4, half-maximal inhibitory concentration: > 100 ug/mL
Compound 4: only a limit was reported; the forecaster's own chance of this, stated with the estimate: 50%; middle value at least 1.2-fold (0.09 log units) away from the limit.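

In this assay compound 4 gives > 100 ug/mL, which is a limit of the assay and not a number. The steps from compound 3 to compound 4 and from compound 1 to compound 4 cannot be read, because both ends of each step are limits: the limit of > 100 ug/mL in this assay, at which 3 of the 4 values shown sit. For the compounds shown here, the methyl change, which on the core of compound 1 gave an at least 2.0-fold lower number from compound 1 to compound 2 (0.30 log units; that floor lies within the scatter), is therefore neither confirmed nor ruled out on the five-membered aromatic ring with 1 oxygen, and the only readable new step, an at least 2.0-fold higher number from compound 2 to compound 4 (0.30 log units; that floor lies within the scatter), compares 3-methylfuran-2-yl with 4-methylphenyl, not the methyl change itself.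

The compounds shown leave open where compound 1, compound 3 and compound 4 would fall if each had a number rather than a limit, so compound 2 remains the only one with a number. They also leave open whether an amine, a carboxylic acid or a longer chain such as ethyl in place of the methyl would give a number in this assay.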